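The source may report more compounds than this note shows. Statements on the series, on what has been measured and on what is new or still open speak of the compounds shown alone.

Measured so far:
compound 1, `C[C@H](NC(=O)CN(c1nc(Cl)nc2[nH]cnc12)C1CC1)C(=O)OCc1ccccc1`: 64.3%
compound 2, `CC(C)[C@H](NC(=O)CN(c1nc(Cl)nc2[nH]cnc12)C1CC1)C(=O)OCc1ccccc1`: 55.5%

Both measured compounds share one core and differ only at the saturated chain carbon bound to an amide-type nitrogen and a carbonyl carbon. In a functional assay on the whole organism (Tail, strain ICR) with Mus musculus as the target, in the tail flick test, with a stated time of 60 min, at a dose of 25 umol/kg by the oral route (a higher number here means a stronger effect of the compound at the dose given, a lower number a weaker effect), compound 1 gives 64.3% and compound 2 gives 55.5%. Compound 2 stands lowest of the two numbers, its nearest neighbour being compound 1, and the step of a number 8.8 percentage points lower from compound 1 to compound 2 (within the scatter) lies within the scatter, so the two cannot be ordered.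

Compound 3, `C[C@@H](O)[C@H](NC(=O)CN(c1nc(Cl)nc2[nH]cnc12)C1CC1)C(=O)OCc1ccccc1`, is not yet measured in this assay. It differs from compound 2 by 1-hydroxyethyl in place of isopropyl on a saturated chain carbon bound to an amide-type nitrogen and a carbonyl carbon. Going by the values given here, the only measured step at the same place is a number 8.8 percentage points lower from compound 1 to compound 2 (within the scatter), within the scatter. Among the compounds with values here, no measured compound carries a 1-hydroxyethyl group, so the expectation rests on that single step alone and on the shared core. The step expected is a number 0.5 percentage points lower from compound 2 to compound 3 (within the scatter), none beyond the scatter. The estimate for compound 3 in this assay is 55%, with a range from 35% to 75%.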

Compound 3, a percentage reported as activity, at one dose (the size of the read-out at that dose, not a potency): 29.7%
Estimate against measurement, compound 3: 25.3 percentage points above, outside the stated range (below it).
By their numbers in this assay, from the lowest: compound 3; then compounds 2 and 1 (each within the scatter of the next).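

At the saturated chain carbon bound to an amide-type nitrogen and a carbonyl carbon, the choice of group can clearly matter in this assay: methyl and isopropyl could not be ordered, but 1-hydroxyethyl gives a number 25.8 percentage points lower from compound 2 to compound 3 (beyond the scatter) and a number 34.6 percentage points lower from compound 1 to compound 3 (beyond the scatter). Isopropyl and 1-hydroxyethyl both have 3 heavy atoms, so that count does not separate them; the change instead exchanges a carbon for an oxygen and adds 1 hydrogen-bond donor, 1 hydrogen-bond acceptor and 1 defined stereocentre, and these compounds cannot show which of these differences goes with the lower number. No measurement available here accounts for the step.

The compounds shown leave open whether the lower number stays with a hydroxymethyl group or returns with 1-methoxyethyl, which keeps the oxygen but lacks the hydroxyl hydrogen, and how an amine or a carboxylic acid at this place would read in this assay. They also leave open whether the opposite configuration at the hydroxyl-bearing carbon of 1-hydroxyethyl would read the same, and the single dose gives the size of the effect at that dose, not a potency.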